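Chloro in place of hydroxy: compound 2 to compound 4

A few compounds are considered here, and "the series" means these few. Any claim that something is new, unique, unknown or untested is made for them only; others in the source may bear on it.

The series shares one core, carried here by compound 1 `COc1cc(NC(C)CCCNC(=O)NNC(=O)Nc2cc(C(F)(F)F)cc(C(F)(F)F)c2)c2ncccc2c1`, compound 2 `COc1cc(NC(C)CCCNC(=O)NNC(=O)Nc2ccc(O)cc2)c2ncccc2c1` and compound 3 `COc1cc(NC(C)CCCNC(=O)NNC(=O)Nc2cccc(Cl)c2)c2ncccc2c1`, which differ only in the aryl group on the amide-type nitrogen. In a functional assay on NCI-H460 cells (Homo sapiens) for inhibition, read by MTT assay, with a stated time of 72 h (a lower number here means a stronger inhibitor, a higher number a weaker inhibitor), compound 1 gives 18000 nM. Compound 3 gives 32000 nM in this assay. Compound 2 reaches only the limit of this assay, reported as > 100000 nM, so that no number of its own is known. This is the limit of > 100000 nM in this assay, at which 1 of the 3 values shown sits, and compound 2 therefore stands at the weak end of the numbers shown. For the measured compounds named here, the single measured step that bears on the new compound is an at least 3.1-fold lower number from compound 2 to compound 3 (0.49 log units; beyond the scatter).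

Compound 4 `COc1cc(NC(C)CCCNC(=O)NNC(=O)Nc2ccc(Cl)cc2)c2ncccc2c1` is compound 2 with chloro in place of hydroxy on an aromatic carbon. Both compound 3 and compound 4 carry a chloro where compound 2 carries a hydroxy, and they differ only as 3-chlorophenyl differs from 4-chlorophenyl. A step of roughly the size of an at least 3.1-fold lower number from compound 2 to compound 3 (0.49 log units; beyond the scatter) is therefore expected for an at least 2.8-fold lower number from compound 2 to compound 4 (0.45 log units; beyond the scatter), toward a lower number, though the two chlorophenyl groups need not give the same number. Compound 4 is expected near 35000 nM, within 12000 nM to 100000 nM.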

Compound 4, half-maximal inhibitory concentration: 63000 nM
Compound 4: the middle estimate sits 1.8-fold (0.26 log units) below what was measured; the measured number falls inside the stated range.
By their numbers in this assay, from the lowest: compounds 1, 3 and 4 (each within the scatter of the next, the first and the last beyond it). At a limit, above all of these: compound 2.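

In this assay, the change at this position reads as an at least 1.5-fold lower number from compound 2 to compound 4 (0.20 log units; that floor lies within the scatter), a floor that does not by itself establish a gain for 4-chlorophenyl over 4-hydroxyphenyl, whereas the earlier step with the chloro in the other placement reads as an at least 3.1-fold lower number from compound 2 to compound 3 (0.49 log units; beyond the scatter). The true size of the step to compound 4 stays unresolved because compound 2 carries only a limit and no number of its own: the limit of > 100000 nM in this assay, at which 1 of the 4 values shown sits. The comparison of the two chlorophenyl groups reads as a 2.0-fold higher number from compound 3 to compound 4 (0.29 log units; within the scatter), so in this assay 3-chlorophenyl and 4-chlorophenyl are not told apart, and the placement of the chloro on this ring has no readable effect so far.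

Still open, on these data alone, is whether a 4-aminophenyl, 4-methoxyphenyl or 4-carboxyphenyl group on the same amide-type nitrogen would stay at the limit reached by compound 2 or give a measurable number. Also open, as far as these compounds go, is how a longer chain in place of the present one on the shared core would read with the 4-chlorophenyl group kept in place.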